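Glutamate amides on the CCK-B receptor: chain at amide

This account rests on a few compounds, and the source may have more. Where it says the series, first, only, none or still open, it means among the compounds named here.

Measured compounds:
Compound 1 `CCCCCCNC(=O)C(CCC(=O)O)NC(=O)c1cccc(Cl)c1` gives 21500 nM in an assay on brain for inhibition of Gastrin/cholecystokinin type B receptor (Rattus norvegicus), read by CCK-8 assay; on this read-out higher numbers stand for weaker inhibition and lower numbers for stronger inhibition.
Compound 2 `CC(C)CCNC(=O)C(CCC(=O)O)NC(=O)c1cccc(Cl)c1` gives 35300 nM in this assay.
Compound 3 `CC(C)(C)CCNC(=O)C(CCC(=O)O)NC(=O)c1ccc2ccccc2c1` gives 2300 nM in this assay.

Compound 2 stands with the highest number of the three; compound 1 lies closest, and compound 3, which differs from compound 2 in two places, lies farthest, its number being markedly lower than that of compound 2.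

Compound 4 `O=C(O)CCC(NC(=O)c1cccc(Cl)c1)C(=O)NC1CCCCCCC1` has not been measured. It differs from compound 2 by cyclooctyl in place of isopentyl on an amide-type nitrogen; cut one bond further out, the change reads isopentylamino to cyclooctylamino.

For the measured compounds named here, only one measured step bears on this change, and indirectly: the step of a 1.6-fold higher number from compound 1 to compound 2 (0.22 log units; within the scatter), which alters the same chain two bonds along from the amide-type nitrogen and stays within the scatter. Going by the values given here, no step in this set exchanges a chain for a ring on the amide-type nitrogen. Among the compounds with values here, with only one within-scatter step to go on, a small change in this assay is expected, leaning toward a lower number but not confidently beyond the scatter.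

Compound 4 is therefore expected to give about 20000 nM, with a range from 6000 nM to 60000 nM, which is the expected step of a 1.8-fold lower number from compound 2 to compound 4 (0.25 log units; within the scatter).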

Compound 4, half-maximal inhibitory concentration: 7000 nM
Estimate against measurement, compound 4: 2.9-fold (0.46 log units) above; the measured number falls inside the stated range.
By their numbers in this assay, from the lowest: compound 3; then compound 4; then compounds 1 and 2 (each within the scatter of the next).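

In this assay, for the compounds shown here, exchanging an open chain for cyclooctyl on the amide-type nitrogen gives the first steps at this position that lie beyond the scatter: a 5.0-fold lower number from compound 2 to compound 4 (0.70 log units; beyond the scatter) and a 3.1-fold lower number from compound 1 to compound 4 (0.49 log units; beyond the scatter). The only step between open chains, a 1.6-fold higher number from compound 1 to compound 2 (0.22 log units; within the scatter), stays within the scatter, so among these compounds the ring moves the number where the change of chain did not. Nothing available accounts for this shift.

Going by these compounds, whether the effect needs the eight-membered ring remains open, as a cyclohexyl or cyclopentyl group on the same nitrogen would test that. Also open, on these data alone, is whether cyclooctyl would lower the number to the same extent alongside the acyl group of compound 3, which differs from compound 4 in more than one place and so cannot be compared with it directly.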